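This account rests on a few compounds, and the source may have more. Where it says the series, first, only, none or still open, it means among the compounds named here.

Measured in an in vitro ADME assay on microsomes from liver (Homo sapiens) for pharmacokinetics, read by LC-MS, with a stated time of 10 min, tested at 1 uM; on this read-out higher numbers stand for fast clearance and lower numbers for slow clearance:
compound 1 `CN1C[C@H](C(=O)Nc2cccc(F)c2)[C@@H](c2ccc(/C=C/C(=O)Nc3ccccc3N)cc2)C1` gives 6 mL/min/kg
compound 2 `CN1C[C@H](C(=O)Nc2cccc(Cl)c2)[C@@H](c2ccc(/C=C/C(=O)Nc3ccccc3N)cc2)C1` gives 7 mL/min/kg
compound 3 `CN1C[C@H](C(=O)Nc2ccc(F)cc2F)[C@@H](c2ccc(/C=C/C(=O)Nc3ccccc3N)cc2)C1` gives 12 mL/min/kg

Compound 4 `CN1C[C@H](C(=O)Nc2ccc(Cl)cc2F)[C@@H](c2ccc(/C=C/C(=O)Nc3ccccc3N)cc2)C1` has not yet been measured in this assay. The change that leads from compound 3 to compound 4 is chloro in place of fluoro on an aromatic carbon. The same kind of change has been made once before, from compound 1 to compound 2: chloro in place of fluoro on an aromatic carbon. There it gave a 1.2-fold higher number from compound 1 to compound 2 (0.07 log units; within the scatter). The surroundings of the exchanged atom are not the same in both cases: in compound 1 the fluoro sits meta to a large group, whereas in compound 3 it sits meta to a fluoro group and para to a large group. The two cores differ as well, by 2,4-difluorophenyl in place of 3-fluorophenyl on an amide-type nitrogen, a difference that gave a 2.0-fold higher number from compound 1 to compound 3 (0.30 log units; within the scatter); the related step of a 1.7-fold higher number from compound 2 to compound 3 (0.23 log units; within the scatter) is likewise within the scatter. Going by the values given here, for compound 4 a step of about the earlier size is expected, a 1.2-fold higher number from compound 3 to compound 4 (0.07 log units; within the scatter), because the one measured instance a 1.2-fold higher number from compound 1 to compound 2 (0.07 log units; within the scatter) barely shifted the number. Compound 4 is therefore estimated at 14 mL/min/kg, with a range from 7 mL/min/kg to 28 mL/min/kg.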

Compound 4, clearance: 11 mL/min/kg
The estimate for compound 4 lay 1.3-fold (0.10 log units) above the measured number, and the stated range covers the measured number.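

In this assay the new step, a 1.1-fold lower number from compound 3 to compound 4 (0.04 log units; within the scatter), is small, and chloro in place of fluoro on an aromatic carbon gives steps on the two cores that do not differ: the same change on two cores in this assay, a 1.2-fold higher number (0.07 log units; within the scatter) from compound 1 to compound 2 and a 1.1-fold lower number (0.04 log units; within the scatter) from compound 3 to compound 4, 1.3-fold (0.10 log units) apart, within the scatter of two such steps. The steps of a 1.6-fold higher number from compound 2 to compound 4 (0.20 log units; within the scatter) and a 1.8-fold higher number from compound 1 to compound 4 (0.26 log units; within the scatter) also lie within the scatter, so this read-out does not separate compound 4 from any of the other three compounds. This supports carrying the change between these two cores only as a change with no detectable effect on clearance; two small steps cannot show that it would stay this small on other cores or in other surroundings.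

Still open, from the compounds shown here alone, is whether a nitrile, a methoxy group or a trifluoromethyl group in place of the chloro would move the number beyond the scatter. Going by these compounds, it is equally open whether an added carboxylic acid or a longer chain in place of the methyl on the shared core would do so.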